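Chloro in place of ethyl: expected effect on inhibition

The source may report more compounds than this note shows. Statements on the series, on what has been measured and on what is new or still open speak of the compounds shown alone.

Two compounds are in hand. Compound 1 `Cc1ccccc1N1CCNC(=O)N1` and compound 2 `CCc1cccc(N2CCNC(=O)N2)c1` share the same core and differ in the group on the aromatic ring and where it sits. In an assay on RBL-1 cells for inhibition of Polyunsaturated fatty acid 5-lipoxygenase (Rattus norvegicus) (on this read-out lower numbers stand for stronger inhibition and higher numbers for weaker inhibition), compound 1 gives 386000 nM, while compound 2 gives 13000 nM. Compound 2 stands at the lower of the two numbers, and compound 1 sits at a higher number, a gap beyond the scatter. Within the data shown here, no single-change step is set out between these two, so only their two values are compared here.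

Compound 3 `O=C1NCCN(c2cccc(Cl)c2)N1` is not yet measured. It differs from compound 2 by chloro in place of ethyl on an aromatic carbon. With both groups carrying no donors, no acceptors and no charge, the expected step in this assay is a 1.2-fold higher number from compound 2 to compound 3 (0.09 log units; within the scatter), within the scatter and in no firm direction. Compound 3 is accordingly estimated at 16000 nM, with a range from 4000 nM to 64000 nM.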

Compound 3, half-maximal inhibitory concentration: 5300 nM
Beside the measured number, compound 3's estimate is 3.0-fold (0.48 log units) above it; the measured number falls inside the stated range.
By their numbers in this assay, from the lowest: compound 3; then compound 2; then compound 1.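

Among these compounds, with the place on the aromatic ring held fixed, chloro in place of ethyl gives a 2.5-fold lower number from compound 2 to compound 3 (0.39 log units; beyond the scatter) in this assay and so provides the first single-change reading. Compound 1 and compound 2 differ in both the group and its place, so their gap could not separate the two; this step shows that the group alone, meta to a group of 7 heavy atoms, can move the number modestly. No measurement in hand accounts for the size or direction of this step.

On these data alone, whether the lower number extends to other groups at this place, such as an amine, a methoxy or a carboxylic acid, remains open. Also open, as far as these compounds go, is whether chloro elsewhere on the aromatic ring would give a similar number.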